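The source may hold more compounds than are shown below. What is called first, only, known or untested is meant among the compounds shown, and "the series" means these compounds.

For the measured compounds named here, in a functional assay on NCI-H460 cells (Homo sapiens) for cytotoxicity, read by sulforhodamine B assay, with a stated time of 24 h (a lower number here means a stronger inhibitor, a higher number a weaker inhibitor), compound 1 `CC(=O)SCCCCC[C@H](NC(=O)[C@H]1CCC(=O)N1)C(=O)Nc1ccccc1` gives 70 nM and compound 2 `CC(=O)SCCCCC[C@H](NC(=O)[C@H]1CCC(=O)N1)C(=O)Nc1cccc(C(F)(F)F)c1` gives 30 nM, which is a 2.3-fold lower number from compound 1 to compound 2 (0.37 log units; beyond the scatter) and the only measured step between compounds that differ in one place. Compound 3 `CC(=O)SCCCCC[C@H](NC(=O)[C@@H]1CCC(=O)N1)C(=O)Nc1cccc(C)c1` gives 60 nM and so sits within the scatter of both compound 1 and compound 2. Set against compound 3, compound 4 `CC(=O)SCCCCC[C@H](NC(=O)[C@H]1CCC(=O)N1)C(=O)Nc1cccc(C)c1` shows the two compounds have the same atoms and bonds and differ only in configuration as drawn: 1 of 2 stereo elements differ; a stereocentre at a saturated ring carbon is drawn S in compound 3 and R in compound 4 and has not yet been tested. Going by the values given here, no measured pair isolates a change of this kind. The step from compound 1 to compound 2 swaps a group on an aromatic carbon, so it bears only indirectly, as a sign of how modest the spread in this small set is. With compound 3 at 60 nM as the starting point, no step beyond the scatter is expected in this assay in either direction, although the data cannot exclude a larger one. The estimate amounts to an expected 1.3-fold lower number from compound 3 to compound 4 (0.12 log units; within the scatter) in this small set. For compound 4 the estimated value is 45 nM with an expected range of 20 nM to 100 nM in this measurement.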

Compound 4, half-maximal inhibitory concentration: 40 nM
Compound 4: middle estimate off by 1.1-fold (0.05 log units), on the high side; the measured number falls inside the stated range.
By their numbers in this assay, from the lowest: compounds 2, 4, 3 and 1 (each within the scatter of the next, the first and the last beyond it).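

In this assay, the first direct test of the stereocentre at the saturated ring carbon gives a 1.5-fold lower number from compound 3 to compound 4 (0.18 log units; within the scatter), so the two drawn configurations cannot be told apart here, and this reading is a clean one for that centre alone: the fact that compounds 3 and 4 differ only in the configuration as drawn

With the configuration of compound 4 held fixed, the group on the aromatic carbon can now be read further: trifluoromethyl to methyl gives a 1.3-fold higher number from compound 2 to compound 4 (0.12 log units; within the scatter), and hydrogen to methyl gives a 1.8-fold lower number from compound 1 to compound 4 (0.24 log units; within the scatter). Methyl therefore cannot be separated from either hydrogen or trifluoromethyl, even though those two groups lie beyond the scatter of each other.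

On these data alone, the stereocentre is tested only with methyl on the aromatic carbon, so whether it counts for as little with trifluoromethyl or hydrogen there remains open. Also open, as far as these compounds go, is how a methoxy group or a carboxylic acid at that carbon would fare.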